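Swapping a sulfonyl for a urea on the piperazine

A few compounds are considered here, and "the series" means these few. Any claim that something is new, unique, unknown or untested is made for them only; others in the source may bear on it.

Measured compounds:
- compound 1 `C=CS(=O)(=O)N1CCN(c2ncnc3sc(-c4cccc5ncccc45)cc23)CC1`: 21000 nM
- compound 2 `C=CS(=O)(=O)N1CCN(c2ncnc3sc(-c4cccs4)cc23)CC1`: 34100 nM
- compound 3 `CN1CCN(c2ccc(-c3cc4c(N5CCN(S(=O)(=O)C6CC6)CC5)ncnc4s3)cc2)CC1`: 11500 nM

In a functional assay on MDA-MB-231 cells (Homo sapiens) for antiproliferative activity, read by MTT assay, with a stated time of 48 h (on this read-out higher numbers stand for weaker inhibition and lower numbers for stronger inhibition), compound 3 gives the lowest of the three numbers shown. Against compound 1 the gap stays within the scatter, so the two cannot be told apart; against compound 2 the gap is beyond the scatter, so compound 3 sits clearly lower than compound 2 on this read-out.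

Compound 4 `CN1CCN(c2ccc(-c3cc4c(N5CCN(C(=O)Nc6ccc(F)cc6F)CC5)ncnc4s3)cc2)CC1` is not yet measured. It differs from compound 3 in one place: (2,4-difluorophenyl)carbamoyl in place of cyclopropylsulfonyl on an amine nitrogen in a ring. For the measured compounds named here, the only measured step, a 1.6-fold higher number from compound 1 to compound 2 (0.21 log units; within the scatter), concerns a change on an aromatic carbon elsewhere in the molecule and therefore does not bear on this exchange. No measured pair speaks to replacing a group on the ring nitrogen, so nothing shown supports expecting a large step in either direction.

The expectation for compound 4 is therefore a step of a 1.0-fold lower number from compound 3 to compound 4 (0.02 log units; within the scatter), that is, no change beyond the scatter. Compound 4 is estimated at 11000 nM, within a range from 3000 nM to 40000 nM.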

Compound 4, half-maximal inhibitory concentration: 11400 nM
Beside the measured number, compound 4's estimate is 1.0-fold (0.02 log units) below it; measured number inside the range.
By their numbers in this assay, from the lowest: compounds 4, 3, 1 and 2 (each within the scatter of the next, the first and the last beyond it).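

For the compounds shown here, the step of a 1.0-fold lower number from compound 3 to compound 4 (0.00 log units; within the scatter) in this assay is the first measured exchange on this amine nitrogen in a ring, and it leaves the two compounds indistinguishable. Here (2,4-difluorophenyl)carbamoyl, with 11 heavy atoms, an aromatic ring and a hydrogen-bond donor, reads the same as cyclopropylsulfonyl, with 6 heavy atoms and no donor, so on this read-out the position tolerates a large difference in the group it carries. Going by these compounds alone, the only earlier step concerned an aromatic carbon, and no evidence at hand explains why these two groups read alike.

From the compounds shown here alone, whether an acetyl group, a benzyl group or the bare ring amine would read the same remains open. So does the role of the two fluorine atoms, which a plain phenylcarbamoyl group would test.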